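The compounds below may be only part of what the source reports. "The series", "measured", "known", "first", "only" and "open" are said of these compounds alone.

Working notes on the series in a toxicity assay on CCRF-CEM cells (Homo sapiens) for cytotoxicity; a higher number here means that more compound is tolerated, a lower number that less compound is tolerated. Compound 1 `Nc1cccc2c1nc(-c1c(F)cccc1F)n2Cc1c(F)cccc1F` gives 26.3 uM. Compound 2 `CC(=O)N(C)c1cccc2c1nc(-c1c(F)cccc1F)n2Cc1c(F)cccc1F` gives > 100 uM, which is a limit and not a number. Compound 3 `CN(C)c1cccc2c1nc(-c1c(F)cccc1F)n2Cc1c(F)cccc1F` gives > 100 uM, which is also a limit. That is the limit of > 100 uM in this assay, at which 2 of the 3 values shown sit.

Compound 4 `N#Cc1cccc2c1nc(-c1c(F)cccc1F)n2Cc1c(F)cccc1F` carries cyano in place of dimethylamino on an aromatic carbon. The bearing steps both start from amino: an at least 3.8-fold higher number from compound 1 to compound 2 (0.58 log units; beyond the scatter) and an at least 3.8-fold higher number from compound 1 to compound 3 (0.58 log units; beyond the scatter). Each lies beyond the scatter, while a step that the two limits leave unreadable from compound 2 to compound 3 cannot be sized. None of them involves cyano, so the guidance is loose, but a high value is expected again without amino. The estimated step, an at least 1.2-fold lower number from compound 3 to compound 4 (0.09 log units; that floor lies within the scatter), is not expected to exceed the scatter. For compound 4 the expected value is 80 uM, with an estimated range from 25 uM to 200 uM.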

Compound 4, half-maximal toxic concentration: 26.7 uM
Estimate against measurement, compound 4: 3.0-fold (0.48 log units) above; measured number inside the range.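

In this assay, losing amino from this aromatic carbon does not by itself give a high reading, since cyano here gives an at least 3.7-fold lower number from compound 3 to compound 4 (0.57 log units; beyond the scatter) and an at least 3.7-fold lower number from compound 2 to compound 4 (0.57 log units; beyond the scatter). Cyano and amino are not separated at this position, with a 1.0-fold higher number from compound 1 to compound 4 (0.01 log units; within the scatter). Compound 2 and compound 3 each stand at a limit and not a number, so the first two steps give only a floor: the limit of > 100 uM in this assay, at which 2 of the 4 values shown sit.

From the compounds shown here alone, the full size of those two steps stays open. Also open, going by these compounds, is how methoxy, a carboxylic acid or a longer chain on this aromatic carbon would read.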